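This account rests on a few compounds, and the source may have more. Where it says the series, first, only, none or still open, it means among the compounds named here.

Compound 1 `CC1(C)[C@@H]2CC[C@@]1(CS(=O)(=O)N1CCN(c3ccccn3)CC1)C(=O)C2` in a functional assay on CHO-K1 cells for antagonist activity at C-X-C chemokine receptor type 3 (Homo sapiens), read by FLIPR and calcium flux (a lower number here means a stronger inhibitor, a higher number a weaker inhibitor), gives > 31600 nM, which is a limit of the assay.
Compound 2 `CC1(C)[C@@H]2CC[C@@]1(CS(=O)(=O)N1CCN(c3ccc(C#N)cn3)CC1)C(=O)C2` gives > 31600 nM, again a limit.
Compound 3 `CC1(C)[C@@H]2CC[C@@]1(CS(=O)(=O)N1CCN(c3ccc(C(F)(F)F)cn3)C(c3ccccc3)C1)C(=O)C2` gives > 31600 nM, also a limit.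

Compound 2 thus stands at the assay limit, as do the other two values shown, summed up in the limit of > 31600 nM in this assay, at which 3 of the 3 values shown sit. Compound 4 `CC1(C)[C@@H]2CC[C@@]1(CS(=O)(=O)N1CCN(c3ccc(C(F)(F)F)nn3)CC1)C(=O)C2` differs from compound 2 by 6-(trifluoromethyl)pyridazin-3-yl in place of 5-cyanopyridin-2-yl on an amine nitrogen in a ring. Among the measured compounds shown here, the only single step measured, a step that the two limits leave unreadable from compound 1 to compound 2, runs between two limits, so its size cannot be read, and no measured step tells how the present change acts in this assay. With every value shown sitting at the limit, compound 4 is expected to return a limit rather than a number, so the step that the limit leaves unreadable from compound 2 to compound 4 is expected to be unreadable. Compound 4 is estimated at 50000 nM, within 20000 nM to 150000 nM.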

Compound 4, half-maximal inhibitory concentration: 5010 nM
Estimate against measurement, compound 4: 10-fold (1.00 log units) above; measured number outside the range, below it.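

Among the compounds shown here, compound 4 is the first compound here to give a true number in this assay, so the group on the amine nitrogen in a ring can move the result off the limit. Placing 6-(trifluoromethyl)pyridazin-3-yl there gives an at least 6.3-fold lower number from compound 2 to compound 4 (0.79 log units; beyond the scatter), and likewise an at least 6.3-fold lower number from compound 1 to compound 4 (0.79 log units; beyond the scatter); both sizes are minimums. The other compounds stay at the limit: the limit of > 31600 nM in this assay, at which 3 of the 4 values shown sit.

On these data alone, whether the gain comes from the pyridazine ring or from the trifluoromethyl group stays open. So does the effect of a methyl group or an amine in place of trifluoromethyl.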